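Dropping the acetyl from a trifluoromethyl ketone hydrate amide

The compounds below may be only part of what the source reports. "The series", "measured", "known", "first", "only" and "open" are said of these compounds alone.

Of the compounds shown here, two have been measured in a functional assay on HCT-116 cells (Homo sapiens) for inhibition, read by colorimetric assay, with a stated time of 3 days; on this read-out higher numbers stand for weaker inhibition and lower numbers for stronger inhibition. Compound 1, `NC(=O)C(=O)NCCCCC(=O)Nc1ccccc1`, gives only a limit: its value of > 100000 nM is the edge of the assay, not a number. Compound 1 thus sits at the limit of > 100000 nM in this assay, at which 1 of the 2 values shown sits. Going by the values given here, compound 2, `CC(=O)c1ccc(NC(=O)CCCCCCNC(=O)C(O)(O)C(F)(F)F)cc1`, carries a trifluoromethyl ketone hydrate at one end of a seven-carbon chain and a 4-acetylphenyl amide at the other; in this assay compound 2 gives 12100 nM, which is the only true number so far.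

Compound 3, `O=C(CCCCCCNC(=O)C(O)(O)C(F)(F)F)Nc1ccccc1`, is the untested partner of compound 2. The change from compound 2 to compound 3 is hydrogen in place of acetyl on an aromatic carbon, so the 4-acetylphenyl becomes a plain phenyl. Among the compounds with values here, no measured pair shows the effect of this change, so the expectation rests on compound 2 alone. The acetyl is a small part of a long molecule, and its loss is expected to cost little, if anything, in this assay. The expected step of a 1.7-fold higher number from compound 2 to compound 3 (0.22 log units; within the scatter) is toward slightly weaker inhibition, hardly beyond the scatter. Compound 3 is therefore estimated at 20000 nM, in a range from 6000 nM to 70000 nM.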

Compound 3, half-maximal inhibitory concentration: 9140 nM
Compound 3: the middle estimate sits 2.2-fold (0.34 log units) above what was measured; the range from low to high includes it.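

Taking off the acetyl gives a 1.3-fold lower number from compound 2 to compound 3 (0.12 log units; within the scatter), so in this assay the two compounds cannot be told apart. Going by these compounds alone, this is the first measured pair, and it shows that the position para to a large group can carry either an acetyl or a plain hydrogen with no change beyond the scatter, even though the 3 heavy atoms and the hydrogen-bond acceptor of the acetyl are gone. The compounds shown offer no measurement that would explain why this swap makes so little difference.

On these data alone, this single pair speaks only for acetyl and hydrogen, so it remains open whether an amine, a carboxylic acid or a nitrile at the same place would also leave the number within the scatter, or would move it clearly in either direction. As far as these compounds go, it also remains open how much the rest of the molecule matters in this assay, for example whether a longer chain or a carboxylic acid in place of the trifluoromethyl ketone hydrate would shift the value.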